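Moving the Thiophene Attachment Point in Compound 4

The source may hold more compounds than are shown below. What is called first, only, known or untested is meant among the compounds shown, and "the series" means these compounds.

- compound 1 `CC1=C(C(=O)OCC(C)C)C(c2cccs2)NC(=O)N1`: in an assay on membranes from HeLa cells for displacement of a labelled ligand from adenosine receptor A3 (Homo sapiens), read by scintillation counting, with a stated time of 180 min, tested at 1 uM (a lower number here means less inhibition, a higher number more inhibition at the concentration tested (going by the name of the read-out)), compound 1 gives 11%
- compound 2 `CC1=C(C(=O)OCC(C)C)C(c2cccs2)NC(=O)N1C`: compound 2 gives 5%
- compound 3 `CC1=C(C(=O)OCc2ccccc2)C(c2cccs2)NC(=O)N1C`: compound 3 gives 18%

Compound 2 stands lowest of the three numbers, though compound 1 lies within the scatter of it and only compound 3 lies beyond it. The unmeasured compound 4 `CC1=C(C(=O)OCC(C)C)C(c2ccsc2)NC(=O)N1C` differs from compound 2 by thiophen-3-yl in place of thiophen-2-yl on a saturated ring carbon. Neither measured step touches this change: a number 6 percentage points lower from compound 1 to compound 2 (within the scatter) concerns the amide-type nitrogen in the ring, and a number 13 percentage points higher from compound 2 to compound 3 (beyond the scatter) concerns the chain on the oxygen next to the carbonyl group. Going by the values given here, no measured step therefore bears on the swap, and the step in this assay from compound 2 to compound 4 is expected to stay within the scatter, in no set direction. Compound 4 is thus estimated at 8%, between 0% and 22%, an expected step of a number 3 percentage points higher from compound 2 to compound 4 (within the scatter).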

Compound 4, a percentage reported as inhibition, at one concentration (the size of the read-out at that concentration, not a potency): 4%
Compound 4: the middle estimate sits 4 percentage points above what was measured; the range from low to high includes it.
By their numbers in this assay, from the lowest: compounds 4, 2, 1 and 3 (each within the scatter of the next, the first and the last beyond it).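

In this assay, thiophen-3-yl in place of thiophen-2-yl on the saturated ring carbon gives a number 1 percentage points lower from compound 2 to compound 4 (within the scatter) and so adds a change at this position to the two steps measured elsewhere on the molecule. With the isobutoxycarbonyl group and the methyl on the ring nitrogen held fixed, the assay does not separate the two attachment points of the thiophene. Nothing shown accounts for this result.

From the compounds shown here alone, whether a pyridyl group or a longer chain on this carbon would shift the number remains open. So does whether the same thiophene swap would stay within the scatter on the core of compound 3 or compound 1.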